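From Pyridin-2-yl to 1H-Imidazol-2-yl: Compound 3

The compounds below may be only part of what the source reports. "The series", "measured", "known", "first", "only" and "open" are said of these compounds alone.

Measured compounds:
compound 1, `N#Cc1cccc(-n2nnc(-c3ccccn3)n2)c1`: 73 nM
compound 2, `COc1cc(C#N)cc(-n2nnc(-c3ccccn3)n2)c1`: 10 nM

Of the compounds shown here, two have been measured in a functional assay with metabotropic glutamate receptor 5 (Rattus norvegicus) as the target; a higher number here means a weaker inhibitor, a lower number a stronger inhibitor. Compound 1 gives 73 nM. Compound 2 gives 10 nM. Going by the values given here, compound 1 therefore stands at the higher of the two numbers, and the one measured step, a 7.3-fold lower number from compound 1 to compound 2 (0.86 log units; beyond the scatter), comes from methoxy in place of hydrogen on an aromatic carbon.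

Compound 3, `N#Cc1cccc(-n2nnc(-c3ncc[nH]3)n2)c1`, differs from compound 1 in another way: 1H-imidazol-2-yl in place of pyridin-2-yl on an aromatic carbon. Among the compounds with values here, no measured step touches this part of the molecule; the step from compound 1 to compound 2 concerns a different group on a different ring, so it gives no guide here. The expectation for compound 3 rests on the structural change alone, and is worded as an estimate: a step of a 2.1-fold higher number from compound 1 to compound 3 (0.31 log units; beyond the scatter), toward a weaker inhibitor, with wide uncertainty. Compound 3 is thus expected at 150 nM, within a range from 30 nM to 800 nM.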

Compound 3, half-maximal inhibitory concentration: 77 nM
Compound 3: the middle estimate sits 1.9-fold (0.29 log units) above what was measured; measured number inside the range.
By their numbers in this assay, from the lowest: compound 2; then compounds 1 and 3 (each within the scatter of the next).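

In this assay, going by these compounds alone, replacing pyridin-2-yl with 1H-imidazol-2-yl gives a 1.1-fold higher number from compound 1 to compound 3 (0.02 log units; within the scatter), the first measured step at this place on the shared core. A five-membered aromatic ring with 2 hetero atoms and 1 hydrogen-bond donor thus reads the same here as a six-membered aromatic ring with 1 hetero atom and no donor, at least for this one pair. No evidence is available that bears on this result.

The compounds shown leave open whether methoxy on the ring bearing the nitrile would give a step like the one seen for compound 2 when 1H-imidazol-2-yl sits at this place. They also leave open how a plain phenyl or a 1-methylimidazol-2-yl group, with a methyl on the ring nitrogen, would read at this place.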